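The source may report more compounds than this note shows. Statements on the series, on what has been measured and on what is new or still open speak of the compounds shown alone.

Measured so far, each only as a limit in a physicochemical assay for solubility; a lower number here means a less soluble compound, a higher number a more soluble compound:

compound 1 `CNC(=O)c1cc(C(=O)NCCC2CCOCC2)cn(Cc2ccccc2)c1=O` — >= 127 ug/mL
compound 2 `CNC(=O)c1ccc(=O)n(Cc2cc(Br)ccc2F)c1` — >= 143 ug/mL
compound 3 `CNC(=O)c1cc(C(=O)NC2CC2)cn(Cc2ccc3nc[nH]c3c2)c1=O` — >= 163 ug/mL

Compound 1 gave a limit of >= 127 ug/mL in this assay. Compound 2 gave a limit of >= 143 ug/mL in this assay. Compound 3 gave a limit of >= 163 ug/mL in this assay. Compound 3 therefore stands at a limit, not at a number, and the two other values shown are limits as well, so no ordering among the three can be drawn from what has been measured.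

Compound 4 `CNC(=O)c1cc(C(=O)NC2CC2)cn(Cc2cccc3[nH]ncc23)c1=O` is the next compound, and it differs from compound 3 in one place: 1H-indazol-4-yl in place of 1H-benzimidazol-6-yl on a saturated chain carbon bound to an aromatic nitrogen

Going by the values given here, no step between measured compounds is available, so there is no measured guide to the size of this change. Because compound 3 sits at the limit of >= 163 ug/mL in this assay, at which 1 of the 3 values shown sits, the expectation for compound 4 rests on that limit alone, and the step of a number no higher from compound 3 to compound 4 (the limit leaves the size open) is expected to be none beyond the scatter. Compound 4 is estimated at 163 ug/mL, with a range from 80 ug/mL to 330 ug/mL, and it may well again be reported only as a limit.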

Compound 4, solubility: 10 ug/mL
Beside the measured number, compound 4's estimate is 16-fold (1.21 log units) above it; measured number outside the range, below it.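

In this assay, 1H-indazol-4-yl in place of 1H-benzimidazol-6-yl on a saturated chain carbon bound to an aromatic nitrogen gives an at least 16-fold lower number from compound 3 to compound 4 (1.21 log units; beyond the scatter). The two groups have the same atoms, the same ring types and the same counts of hydrogen-bond donors and acceptors, and differ only in how those atoms are joined, so this position responds to a change that leaves all of those counts untouched. Going by these compounds alone, compound 4 is also the first compound here to give a number rather than a limit, and the value of compound 3 remains a limit, so the true size of the step stays open.

Nothing measured here explains why the two groups differ so strongly. Going by these compounds, it also remains open whether 1H-indazol-5-yl, or 1H-indazol-4-yl carrying a carboxylic acid or an amine, would give a number as low as that of compound 4.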